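The source may report more compounds than this note shows. Statements on the series, on what has been measured and on what is new or still open speak of the compounds shown alone.

Of the compounds shown here, three have been measured in a functional assay on MCF7 cells (Homo sapiens) for inhibition; on this read-out lower numbers stand for stronger inhibition and higher numbers for weaker inhibition. Compound 1 `CC1=NNC(=O)/C1=N/Nc1cccc(-c2nc3ccccc3s2)c1` gives > 25000 nM; that figure is a limit of the assay and not a number. Compound 2 `O=C(CSc1nc2ccc(NC(=O)CCl)cc2s1)NCc1ccccc1` gives 4200 nM. Compound 3 `CC(=O)N1N=C(C)/C(=N\Nc2cccc(-c3nc4ccccc4s3)c2)C1=O` gives 12300 nM, the highest of the two numbers shown; its nearest neighbour is compound 2, whose number is lower by a gap beyond the usual scatter. Among the compounds with values here, the only step between measured compounds that differ in a single place, an at least 2.0-fold lower number from compound 1 to compound 3 (0.30 log units; that floor lies within the scatter), puts acetyl in place of hydrogen on an amide-type nitrogen in a ring; its size rests on (the limit of > 25000 nM in this assay, at which 1 of the 3 values shown sits), so only its floor is known, and that floor lies within the scatter.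

Compound 4 `CC1=NN(c2ccccc2)C(=O)/C1=N/Nc1cccc(-c2nc3ccccc3s2)c1` is not yet measured. It differs from compound 3 as follows: phenyl in place of acetyl on an amide-type nitrogen in a ring. The change sits on the amide-type nitrogen in a ring that the measured step also touched, but that step exchanged hydrogen rather than acetyl, and its size is known only as a floor, so it gives little guidance on how large a change to expect or in which direction. Compound 4 is therefore expected to land near compound 3, with the expected step of a 1.2-fold lower number from compound 3 to compound 4 (0.09 log units; within the scatter) staying within the scatter. The estimate for compound 4 is 10000 nM, with a range from 3000 nM to 30000 nM.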

Compound 4, half-maximal inhibitory concentration: 12300 nM
For compound 4 the middle estimate is 1.2-fold (0.09 log units) below the measured one; low and high end bracket the measured number.
By their numbers in this assay, from the lowest: compound 2; then compounds 3 and 4 (each within the scatter of the next). At a limit, above all of these: compound 1.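

In this assay, the step on the amide-type nitrogen in a ring is no change at the digits printed from compound 3 to compound 4 (within the scatter), even though the group that enters, phenyl, has 6 heavy atoms and a six-membered aromatic ring of carbon only, while the acetyl that leaves has 3 heavy atoms and no ring. Within the data shown here, until now this nitrogen had been seen only with hydrogen and acetyl, so this is the first sign that two quite different groups can sit there and give the same reading. The comparison with the compound that carries hydrogen at this nitrogen is an at least 2.0-fold lower number from compound 1 to compound 4 (0.30 log units; that floor lies within the scatter), and as with acetyl, only the floor of that step is known: the limit of > 25000 nM in this assay, at which 1 of the 4 values shown sits.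

Going by these compounds, how far hydrogen truly lies from acetyl and phenyl therefore stays open, since the figure for compound 1 is a limit and not a number. Also open, on these data alone, is whether anything placed on this nitrogen can shift the reading at all, for example an amine on a longer chain, a carboxylic acid, or a phenyl ring that carries a methoxy group.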